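Cyclopentyl in Place of Phenyl on the Ring Nitrogen

The source may hold more compounds than are shown below. What is called first, only, known or untested is meant among the compounds shown, and "the series" means these compounds.

Measured compounds:
compound 1 `O=[N+]([O-])c1cc(S(=O)(=O)C(F)(F)F)ccc1NC1CCCCC1`: > 1000000 nM
compound 2 `O=[N+]([O-])c1cc(S(=O)(=O)C(Cl)(Cl)Br)ccc1Nc1ccccc1`: 7200 nM
compound 3 `O=[N+]([O-])c1cc(S(=O)(=O)C(Cl)(Cl)Br)ccc1NCCCCc1ccccc1`: 6000 nM

In an assay on cells for inhibition of serine/threonine-protein kinase WNK1 (Homo sapiens), read by scintillation counting and 33P incorporation, with a stated time of 30 min (on this read-out lower numbers stand for stronger inhibition and higher numbers for weaker inhibition), compound 2 gives 7200 nM, the higher of the two numbers shown. Compound 3 gives 6000 nM, which lies within the scatter of compound 2. For compound 1 the result is only a limit of the assay, (the limit of > 1000000 nM in this assay, at which 1 of the 3 values shown sits).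

Compound 4 `O=[N+]([O-])c1cc(S(=O)(=O)C(Cl)(Cl)Br)ccc1NC1CCCC1` differs from compound 2 by cyclopentyl in place of phenyl on a nitrogen on an aromatic ring. Among the measured compounds shown here, no measured pair shows this kind of change, so its size is not known from the data. Because compound 1 sits at the limit of > 1000000 nM in this assay, at which 1 of the 3 values shown sits, a weakening beyond the scatter is expected. The step from compound 2 to compound 4 is expected to be a 6.9-fold higher number from compound 2 to compound 4 (0.84 log units; beyond the scatter), so compound 4 is estimated at 50000 nM, in a range from 8000 nM to 1000000 nM.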

Compound 4, half-maximal inhibitory concentration: 6500 nM
For compound 4 the middle estimate is 7.7-fold (0.89 log units) above the measured one, and the stated range ends above it.
By their numbers in this assay, from the lowest: compounds 3, 4 and 2 (each within the scatter of the next). At a limit, above all of these: compound 1.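

In this assay cyclopentyl in place of phenyl on a nitrogen on an aromatic ring gives a 1.1-fold lower number from compound 2 to compound 4 (0.04 log units; within the scatter) and so the read-out does not tell the two groups apart at this place. The earlier compounds shown here formed no step and could not show this; here an aromatic ring on this nitrogen proves not to be needed in this pair. Nothing measured here gives a cause for this result. As far as these compounds go, it remains open how an amine or a carboxylic acid carried on the cyclopentyl would read, and how a methyl on this nitrogen would compare.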